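Changing the Aromatic Group on a Shared Lactam Core

The source may report more compounds than this note shows. Statements on the series, on what has been measured and on what is new or still open speak of the compounds shown alone.

Measured compounds:
compound 1 `COc1ccccc1-n1cc(CN2C(=O)C[C@@H]3CC[C@@]2(C)C3(C)C)nn1` gives 280 nM
compound 2 `COc1ccc(-n2cc(CN3C(=O)C[C@@H]4CC[C@@]3(C)C4(C)C)nn2)cc1` gives 480 nM
compound 3 `CC1(C)[C@H]2CC[C@]1(C)N(Cc1cn(-c3ccc(F)cc3)nn1)C(=O)C2` gives 500 nM

In a functional assay on SGC-7901 cells (Homo sapiens) for inhibition, read by MTT assay, with a stated time of 24 h (on this read-out lower numbers stand for stronger inhibition and higher numbers for weaker inhibition), compound 1 has the lowest of the three numbers, yet the steps of a 1.7-fold higher number from compound 1 to compound 2 (0.23 log units; within the scatter) and a 1.8-fold higher number from compound 1 to compound 3 (0.25 log units; within the scatter) both fall within the scatter, so no ranking among the three is warranted. Compound 4 `CC1(C)[C@H]2CC[C@]1(C)N(Cc1cn(-c3cccc(O)c3)nn1)C(=O)C2` keeps the shared core and differs from compound 1 only at the aromatic nitrogen: 3-hydroxyphenyl in place of 2-methoxyphenyl on an aromatic nitrogen. The relevant precedents are the exchanges of that same aromatic group, a 1.7-fold higher number from compound 1 to compound 2 (0.23 log units; within the scatter) and a 1.8-fold higher number from compound 1 to compound 3 (0.25 log units; within the scatter), together with a 1.0-fold higher number from compound 2 to compound 3 (0.02 log units; within the scatter); each stayed within the scatter. Among the measured compounds shown here, a move to 3-hydroxyphenyl has no direct precedent here, but the step of a 1.4-fold higher number from compound 1 to compound 4 (0.15 log units; within the scatter) is expected to be small. Compound 4 is estimated at 400 nM, between 150 nM and 1200 nM.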

Compound 4, half-maximal inhibitory concentration: 270 nM
For compound 4 the middle estimate is 1.5-fold (0.17 log units) above the measured one; measured number inside the range.
By their numbers in this assay, from the lowest: compounds 4, 1, 2 and 3 (each within the scatter of the next).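

In this assay the move to 3-hydroxyphenyl adds a hydrogen-bond donor on the ring at this aromatic nitrogen, and all three steps stay within the scatter (a 1.0-fold lower number from compound 1 to compound 4 (0.02 log units; within the scatter); a 1.8-fold lower number from compound 2 to compound 4 (0.25 log units; within the scatter); a 1.9-fold lower number from compound 3 to compound 4 (0.27 log units; within the scatter)). This position therefore accepts a ring with a donor as well as the earlier rings carrying methoxy or fluoro, with no separation among the four compounds. No measurement at hand explains this result. Still open, as far as these compounds go, is whether a ring bearing an amine or a carboxylic acid, or a longer chain in place of the ring, would produce a step beyond the scatter.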